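A few compounds are considered here, and "the series" means these few. Any claim that something is new, unique, unknown or untested is made for them only; others in the source may bear on it.

Among the measured compounds shown here, in a functional assay on HUVEC cells (Homo sapiens) for inhibition (a higher number here means a weaker inhibitor, a lower number a stronger inhibitor), compound 1 (`CN(c1ccc(NC(=N)Nc2ccccc2)cc1)c1ccnc(Nc2cccc(CS(C)(=O)=O)c2)n1`) gives 596 nM, the highest number of the three measured so far. Compound 2 (`CN(c1ccc(NC(=O)Nc2ccc(OC(F)(F)F)cc2)cc1)c1ccnc(Nc2cccc(S(N)(=O)=O)c2)n1`) reads 5 nM and compound 3 (`CN(c1ccc(NC(=O)Nc2ccc(OC(F)(F)F)cc2)cc1)c1ccnc(Nc2ccc(S(N)(=O)=O)cc2)n1`) reads 37 nM. Compound 4 (`CN(C)CCNC(=O)Nc1ccc(N(C)c2ccnc(Nc3cccc(CS(C)(=O)=O)c3)n2)cc1`) departs from compound 1 by one change on a nitrogen on an aromatic ring: a group of 8 heavy atoms (5 carbon, 2 nitrogen, 1 oxygen; no ring) in place of a group of 9 heavy atoms (7 carbon, 2 nitrogen; one six-membered aromatic ring of carbon only), on a nitrogen on an aromatic ring. For the measured compounds named here, the only measured step, a 7.4-fold higher number from compound 2 to compound 3 (0.87 log units; beyond the scatter), swaps 4-sulfamoylphenyl for 3-sulfamoylphenyl and leaves the exchanged group untouched, so it shows only the size a single change can reach in this assay. It gives no direction here, so no shift beyond the scatter is firmly expected. The expected step is a 1.2-fold lower number from compound 1 to compound 4 (0.08 log units; within the scatter), and it is uncertain. For compound 4 the estimate is 500 nM, with an expected range of 100 nM to 2500 nM.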

Compound 4, half-maximal inhibitory concentration: 530 nM
Compound 4: the middle estimate sits 1.1-fold (0.03 log units) below what was measured, and the stated range covers the measured number.
By their numbers in this assay, from the lowest: compound 2; then compound 3; then compounds 4 and 1 (each within the scatter of the next).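

At the place on a nitrogen on an aromatic ring, replacing the ring-bearing group with the open (2-(dimethylamino)ethyl)carbamoyl chain gives a 1.1-fold lower number from compound 1 to compound 4 (0.05 log units; within the scatter) in this assay, so the two compounds cannot be told apart. For this pair, then, a six-membered aromatic ring of carbon only is not required at this position to keep the reading in the same range. No available evidence explains this result. The compounds shown leave open whether a carboxylic acid or a longer chain at this place would read alike. They also cannot separate the loss of the ring from the arrival of the dimethylamino group, as both occur in this one step.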